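A few compounds are considered here, and "the series" means these few. Any claim that something is new, unique, unknown or untested is made for them only; others in the source may bear on it.

Measured so far: compound 1 `CCN(CC)CN1C(=O)/C(=N\NC(=S)NO)c2cc(F)ccc21` with 521000 nM; compound 2 `CN(C)CN1C(=O)/C(=N\NC(=S)NO)c2cc(Cl)ccc21` with 610000 nM; compound 3 `CONC(=S)N/N=C1\C(=O)N(CN(C)C)c2ccc(Cl)cc21` with 552000 nM, all in an ADME assay on MT4 cells (Homo sapiens) for cytotoxicity, read by spectrophotometry, with a stated time of 5 days; a higher number here means that more compound is tolerated, a lower number that less compound is tolerated.

Compound 2 and compound 3 differ by methyl in place of hydrogen on an oxygen, and this change gave a 1.1-fold lower number from compound 2 to compound 3 (0.04 log units; within the scatter). Compound 1 shares its core with compound 2 only in part; how the two cores differ is not broken down here. For the measured compounds named here, compound 4 `CCN(CC)CN1C(=O)/C(=N\NC(=S)NOC)c2cc(F)ccc21` is not yet measured and differs from compound 1 by methyl in place of hydrogen on an oxygen, the same change as the one made from compound 2 to compound 3.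

Because the earlier step was a 1.1-fold lower number from compound 2 to compound 3 (0.04 log units; within the scatter), the step from compound 1 to compound 4 in this assay is expected to be about as small: a 1.1-fold lower number from compound 1 to compound 4 (0.04 log units; within the scatter). Compound 4 is therefore expected to give roughly 480000 nM, between 300000 nM and 800000 nM.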

Compound 4, half-maximal cytotoxic concentration: 490000 nM
Estimate against measurement, compound 4: 1.0-fold (0.01 log units) below; the measured number falls inside the stated range.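

In this assay, putting methyl in place of hydrogen on the oxygen, which turns hydroxyamino into methoxyamino, gave a 1.1-fold lower number from compound 1 to compound 4 (0.03 log units; within the scatter), so the number stayed within the usual scatter. Set beside the earlier step, the same change behaved alike on the two cores: the same change on two cores in this assay, a 1.1-fold lower number (0.04 log units; within the scatter) from compound 2 to compound 3 and a 1.1-fold lower number (0.03 log units; within the scatter) from compound 1 to compound 4, 1.0-fold (0.02 log units) apart, within the scatter of two such steps. This agreement covers only these two pairs of compounds in this one measurement, and with steps this small it does not show that the change would stay as small on any other core.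

The compounds shown leave open what a longer chain such as propyl would do on that oxygen. They also leave open whether an amine or a carboxylic acid carried there would shift the number beyond the scatter.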